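The source may hold more compounds than are shown below. What is called first, only, known or untested is meant among the compounds shown, and "the series" means these compounds.

Measured so far: compound 1 `COc1ccc(C(=O)ON=C2CC(c3ccc(O)c(OC)c3)N(C)C(c3ccc(O)c(OC)c3)C2)cc1`, 33000 nM; compound 2 `COc1cc(C2CC(=NOC(=O)c3ccc(Br)cc3)CC(c3ccc(O)c(OC)c3)N2C)ccc1O`, 108000 nM.

In a functional assay, read by spectrophotometry, with a stated time of 30 min (on this read-out lower numbers stand for stronger inhibition and higher numbers for weaker inhibition), compound 2 gives 108000 nM, the highest of the two numbers in hand; the nearest is compound 1 with 33000 nM, and the step of a 3.3-fold higher number from compound 1 to compound 2 (0.51 log units; beyond the scatter) runs beyond the scatter. Compound 3 `COc1cc(C2CC(=NO)CC(c3ccc(O)c(OC)c3)N2C)ccc1O` is not yet measured. It differs from compound 2 by hydrogen in place of (4-bromophenyl)carbonyl on an oxygen, so the ester is removed entirely and the free oxime remains. Within the data shown here, the only measured step, a 3.3-fold higher number from compound 1 to compound 2 (0.51 log units; beyond the scatter), concerns a change within the aryl group that is itself removed here, so it bears only loosely on this step; no measured pair shows what removing the acyl group does. Both measured compounds are weak in this assay, and compound 1 carries the smaller of the two numbers. On this thin footing compound 3 is expected to land somewhere between the two measured values, with the step of a 2.2-fold lower number from compound 2 to compound 3 (0.33 log units; beyond the scatter) taken as the estimate. The estimate for compound 3 is 50000 nM, with a range from 12000 nM to 200000 nM.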

Compound 3, half-maximal inhibitory concentration: 158000 nM
Compound 3: middle estimate off by 3.2-fold (0.50 log units), on the low side; the range from low to high includes it.
By their numbers in this assay, from the lowest: compound 1; then compounds 2 and 3 (each within the scatter of the next).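

In this assay the effect of removing the acyl group from the oxime oxygen can now be read directly: hydrogen in place of (4-bromophenyl)carbonyl gives a 1.5-fold higher number from compound 2 to compound 3 (0.17 log units; within the scatter) and so separates the free oxime from this ester by no measurable margin. Hydrogen in place of (4-methoxyphenyl)carbonyl gives a 4.8-fold higher number from compound 1 to compound 3 (0.68 log units; beyond the scatter) as a modest step, so acylation of this oxygen does not by itself lower the number, and only the methoxy-bearing ester stands apart from the free oxime. No available evidence accounts for this difference between the two esters.

On these data alone, it remains open whether a small acetyl group or a benzyl ether on this oxygen would behave like either ester or like the free oxime. As far as these compounds go, the reach of the aryl substituent is also open, for example with a dimethylamino group on the benzoyl ring.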